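The source may report more compounds than this note shows. Statements on the series, on what has been measured and on what is new or still open speak of the compounds shown alone.

The measured compounds, with their values in a physicochemical assay for lipophilicity; a higher number here means a more lipophilic compound, a lower number a more polar compound:

Compound 1, `CCOC(=O)/C=C(C)/C=C/CC(C)CCC(OC)C(C)C`, gives 5.54.
Compound 2, `COC(CCC(C)C/C=C/C(C)=C/C(=O)OC(C)C)C(C)C`, gives 5.95.
Compound 3, `CCCC(=O)/C=C(C)/C=C/CC(C)CCCC(C)C`, gives 6.81.

Compound 4, `CC(/C=C/CC(C)CCCC(C)C)=C\C(=O)CC(C)C`, has not yet been measured.

Compounds 1 and 2 differ in a single place: methyl in place of hydrogen on a saturated chain carbon bound to an oxygen next to a carbonyl group and a saturated chain carbon. That change produced a number 0.41 log units higher from compound 1 to compound 2 (beyond the scatter). Compound 3 stands highest of the three measured numbers, and the difference between its core and the core of compound 1 is not broken down here. Compound 4 differs from compound 3 in a single place as well: methyl in place of hydrogen on a saturated chain carbon bound to two saturated chain carbons. The two places are not identical. In compound 2 the methyl enters on a saturated chain carbon bound to an oxygen next to a carbonyl group and a saturated chain carbon, whereas in compound 4 it enters on a saturated chain carbon bound to two saturated chain carbons. The two are therefore the same kind of change, not the same change. Still, one carbon is added in both cases without any donor, acceptor or ring, and a step of about the same size is expected for compound 4 because the earlier one gave a number 0.41 log units higher from compound 1 to compound 2 (beyond the scatter). The step from compound 3 to compound 4 is expected to be a number 0.45 log units higher from compound 3 to compound 4 (beyond the scatter). Compound 4 is thus expected to reach 7.26. For compound 4 the expected range runs from 6.9 to 7.6.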

Compound 4, partition coefficient: 7.22
Beside the measured number, compound 4's estimate is 0.04 log units above it, and the stated range covers the measured number.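

In this assay, methyl in place of hydrogen on a saturated chain carbon bound to two saturated chain carbons gives a number 0.41 log units higher from compound 3 to compound 4 (beyond the scatter) and thus turns propylcarbonyl into isobutylcarbonyl, while the earlier methyl, placed on a saturated chain carbon bound to an oxygen next to a carbonyl group and a saturated chain carbon, gave a number 0.41 log units higher from compound 1 to compound 2 (beyond the scatter) on another core. The two steps are printed with the same size, so in these two pairs the gain from one added carbon carried over from one core to another, even though the place of the change was not the same. Within the data shown here, this is no general rule, however, as it rests on only two pairs, both compared in a single assay, and nothing measured here explains why the two steps match.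

The compounds shown leave open whether the same methyl would give a step of this size on a core carrying an amine or a carboxylic acid. They also leave open whether the step would stay the same if a longer chain took the place of the isobutylcarbonyl group in compound 4.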